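Phenyl in Place of Methyl on the Shared Core

The source may hold more compounds than are shown below. What is called first, only, known or untested is meant among the compounds shown, and "the series" means these compounds.

Compound 1 `CC/N=C(\S)CCn1nc(-c2ccccc2)ccc1=O` and compound 2 `Cc1ccc(=S)n(CCC(=N)S)n1` were both tested in a functional assay on the whole organism (stomach) with Rattus norvegicus as the target; on this read-out lower numbers stand for an effect already at smaller amounts and higher numbers for an effect only at larger amounts of compound. In this assay compound 1 gives 100 mg/kg. In this assay compound 2 gives 100 mg/kg, level with compound 1 within the scatter. Compound 3 `N=C(S)CCn1nc(-c2ccccc2)ccc1=S` differs from compound 2 by phenyl in place of methyl on an aromatic carbon. Going by the values given here, no pair of measured compounds isolates this change. Compound 1 also carries a phenyl and gives 100 mg/kg, so the step of no change at the digits printed from compound 2 to compound 3 (within the scatter) is expected to stay within the scatter. Compound 3 is therefore expected to give 100 mg/kg in this assay, with a range from 50 mg/kg to 200 mg/kg.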

Compound 3, dose for half-maximal effect: 73.4 mg/kg
Estimate against measurement, compound 3: 1.4-fold (0.13 log units) above; measured number inside the range.
By their numbers in this assay, from the lowest: compounds 3, 1 and 2 (each within the scatter of the next).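

In this assay, going by these compounds alone, phenyl in place of methyl on this aromatic carbon gives a 1.4-fold lower number from compound 2 to compound 3 (0.13 log units; within the scatter), the first direct reading of this change on the shared core. The position therefore takes a phenyl as well as a methyl, with no difference beyond the scatter in this read-out. Nothing at hand bears on why the two compounds read this way.

The compounds shown leave open whether an amine, a carboxylic acid or a longer chain at this position would move the number beyond the scatter. They also leave open how a substituted phenyl would read here.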